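The source may report more compounds than this note shows. Statements on the series, on what has been measured and on what is new or still open speak of the compounds shown alone.

Measured in a functional assay on MOLT-4 cells (Homo sapiens) for antiproliferative activity; on this read-out lower numbers stand for stronger inhibition and higher numbers for weaker inhibition:
compound 1 `COc1cc(C(=O)c2sc(-c3ccc(I)cc3)cc2N)cc(OC)c1OC`: 190 nM
compound 2 `COc1cc(C(=O)c2sc(-c3cccc([N+](=O)[O-])c3)cc2N)cc(OC)c1OC`: 7.5 nM
compound 3 `COc1cc(C(=O)c2sc(-c3ccc(Cl)c(Cl)c3)cc2N)cc(OC)c1OC`: 270 nM

Compound 3 shares the high end of these numbers with compound 1, as the data show a 1.4-fold higher number from compound 1 to compound 3 (0.15 log units; within the scatter). Against compound 2 the picture differs, with a 36-fold higher number from compound 2 to compound 3 (1.56 log units; beyond the scatter). Compound 4 `CCOc1ccc(-c2cc(N)c(C(=O)c3cc(OC)c(OC)c(OC)c3)s2)cc1` brings one change: 4-ethoxyphenyl in place of 3,4-dichlorophenyl on an aromatic carbon. The 4-ethoxyphenyl group has not been measured on this core, so only the other swaps at this place bear on it. They range from the small step above to a 25-fold lower number from compound 1 to compound 2 (1.40 log units; beyond the scatter), so a swap here can matter greatly or barely at all. In this assay the expected step is a 5.4-fold lower number from compound 3 to compound 4 (0.73 log units; beyond the scatter), a moderate move to a lower number with wide uncertainty. For compound 4 the estimated value is 50 nM. The expected range for compound 4 runs from 10 nM to 250 nM.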

Compound 4, half-maximal inhibitory concentration: 240 nM
The estimate for compound 4 lay 4.8-fold (0.68 log units) below the measured number, and the stated range covers the measured number.
By their numbers in this assay, from the lowest: compound 2; then compounds 1, 4 and 3 (each within the scatter of the next).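

In this assay, 4-ethoxyphenyl proves no better than 3,4-dichlorophenyl at this place next to the ring sulfur (a 1.1-fold lower number from compound 3 to compound 4 (0.05 log units; within the scatter)), and compound 4 also matches compound 1 (a 1.3-fold higher number from compound 1 to compound 4 (0.10 log units; within the scatter)). Three different groups now sit together here, so the 3-nitrophenyl of compound 2 stands alone (a 32-fold higher number from compound 2 to compound 4 (1.51 log units; beyond the scatter)). No evidence on hand accounts for this.

As far as these compounds go, whether the lower number of compound 2 depends on the nitro group itself or on where it sits on the phenyl ring stays open. So does what an amine or a carboxylic acid on that phenyl ring would give.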